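Moving the hydroxyl on the azepane sulfonamide

The source may hold more compounds than are shown below. What is called first, only, known or untested is meant among the compounds shown, and "the series" means these compounds.

Compound 1 `O=C(Nc1ccc(F)c(Cl)c1)c1ccc(F)c(S(=O)(=O)N2CCCCCCC2O)c1`: 7000 nM
Compound 2 `CN1CCN(S(=O)(=O)c2cc(C(=O)Nc3ccc(F)c(Cl)c3)ccc2F)CC(O)C1`: 31000 nM
Compound 3 `O=C(Nc1ccc(F)c(Cl)c1)c1ccc(F)c(S(=O)(=O)N2CCCCC(O)C2)c1`: 15000 nM

In an ADME assay on HepG2 2.2.15 cells (Homo sapiens) for cytotoxicity, read by luminescence, with a stated time of 3 days (a lower number here means that less compound is tolerated, a higher number that more compound is tolerated), compound 3 stands second highest of the three numbers, with compound 2 above it and compound 1 below it. Compound 4 `O=C(Nc1ccc(F)c(Cl)c1)c1ccc(F)c(S(=O)(=O)N2CCCC(O)CC2)c1` differs from compound 3 in one place: 4-hydroxyazepan-1-yl in place of 3-hydroxyazepan-1-yl on a sulfonyl sulfur. The two steps that end at compound 3 are a 2.1-fold higher number from compound 1 to compound 3 (0.33 log units; beyond the scatter) and a 2.1-fold lower number from compound 2 to compound 3 (0.32 log units; beyond the scatter), both modest, and each of them changes the ring itself rather than the place of the hydroxyl. The remaining step, a 4.4-fold higher number from compound 1 to compound 2 (0.65 log units; beyond the scatter), is also modest. Going by the values given here, the change to compound 4 keeps the ring and moves only the hydroxyl, and no measured step tests such a move. The expected step in this assay is therefore no change at the digits printed from compound 3 to compound 4 (within the scatter), not beyond the scatter in either direction. Compound 4 is thus estimated to give 15000 nM in this assay, with a range from 7000 nM to 31000 nM.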

Compound 4, half-maximal cytotoxic concentration: 29000 nM
Estimate against measurement, compound 4: 1.9-fold (0.29 log units) below, and the stated range covers the measured number.
By their numbers in this assay, from the lowest: compound 1; then compounds 3, 4 and 2 (each within the scatter of the next, the first and the last beyond it).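

In this assay, moving the hydroxyl while keeping the seven-membered ring gives a 1.9-fold higher number from compound 3 to compound 4 (0.29 log units; within the scatter), so this first test of the hydroxyl's place alone does not separate 4-hydroxyazepan-1-yl from 3-hydroxyazepan-1-yl. Exchanging 6-hydroxy-4-methyl-1,4-diazepan-1-yl for 4-hydroxyazepan-1-yl on the sulfonyl sulfur gives a 1.1-fold lower number from compound 2 to compound 4 (0.03 log units; within the scatter) and likewise lies within the scatter, although the corresponding exchange for 3-hydroxyazepan-1-yl was printed as just beyond it. The eight-membered ring of compound 1 remains apart, with a 4.1-fold higher number from compound 1 to compound 4 (0.62 log units; beyond the scatter) and compound 1 lowest of the four.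

From the compounds shown here alone, whether a methoxy group or an amine in place of the hydroxyl on the azepane would change the number stays open, as does the reading for plain azepan-1-yl. Nothing in the material shown accounts for these numbers.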